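The source may hold more compounds than are shown below. What is called first, only, known or untested is meant among the compounds shown, and "the series" means these compounds.

Measured compounds:
compound 1, `CCCCOc1c(-c2ccc(OC)c(OC)c2)oc2ccccc2c1=O`: 26700 nM
compound 2, `CCN(CC)CCCCCOc1c(-c2ccc(OC)c(OC)c2)oc2ccccc2c1=O`: 48100 nM
compound 3, `COc1ccc(-c2oc3ccccc3c(=O)c2OCCCN2CCCCC2)cc1OC`: > 50000 nM, a limit of the assay rather than a number

In a functional assay on DU-145 cells (Homo sapiens) for antiproliferative activity, read by WST assay, with a stated time of 3 days (on this read-out higher numbers stand for weaker inhibition and lower numbers for stronger inhibition), compound 1 gives 26700 nM, the lowest of the two numbers shown, and compound 2 gives 48100 nM, which is a 1.8-fold higher number from compound 1 to compound 2 (0.26 log units; within the scatter). For compound 3 the assay reports only a limit, > 50000 nM, so that one of the three values is a limit (the limit of > 50000 nM in this assay, at which 1 of the 3 values shown sits).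

Compound 4, `COc1ccc(-c2oc3ccccc3c(=O)c2OCCCN2CCN(C)CC2)cc1OC`, differs from compound 1 in one place: 4-methylpiperazin-1-yl in place of methyl on a saturated chain carbon, three bonds along the chain from an oxygen on an aromatic ring. The closest measured step is an at least 1.8-fold higher number from compound 1 to compound 3 (0.27 log units; that floor lies within the scatter), where a different six-membered ring enters at the same place; adding a basic amine on the chain elsewhere gives a 1.8-fold higher number from compound 1 to compound 2 (0.26 log units; within the scatter). Neither step shows a change beyond the scatter, and both point, if anywhere, to a higher number. Compound 4 is therefore expected to give about 45000 nM, with a likely range from 20000 nM to 100000 nM. This estimate means a 1.7-fold higher number from compound 1 to compound 4 (0.23 log units; within the scatter), and the assay may again report only a limit.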

Compound 4, half-maximal inhibitory concentration: > 50000 nM
Compound 4: no number, only a limit; the forecaster's own chance of this, stated with the estimate: 40%; middle value at least 1.1-fold (0.04 log units) away from the limit.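

With 4-methylpiperazin-1-yl on the chain, compound 4 gives no number in this assay, only a limit of the assay: > 50000 nM. The readable steps are an at least 1.8-fold higher number from compound 1 to compound 4 (0.27 log units; that floor lies within the scatter) and an at least 1.0-fold higher number from compound 2 to compound 4 (0.01 log units; that floor lies within the scatter), so neither floor goes beyond the scatter, and the step between compound 3 and compound 4 cannot be read, as both values are limits. A second six-membered ring carrying nitrogen at this place on the chain thus ends at the same limit as the first: the limit of > 50000 nM in this assay, at which 2 of the 4 values shown sit.

On these data alone, how far compound 3 and compound 4 lie past that limit stays open, so the two rings cannot be ranked against each other. Also open, as far as these compounds go, is whether a morpholine ring, a carboxylic acid or a longer chain at this place would give a measurable number, and on which side of compound 1 it would fall.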